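From isobutyl to cyclopentyl on compound 2

A few compounds are considered here, and "the series" means these few. Any claim that something is new, unique, unknown or untested is made for them only; others in the source may bear on it.

Measured in a functional assay on HCT-116 cells (Homo sapiens) for antiproliferative activity, read by MTT assay, with a stated time of 72 h; on this read-out lower numbers stand for stronger inhibition and higher numbers for weaker inhibition
- compound 1 (`N=C(NC(=N)NC1CCCC1)Nc1ccc(C(F)(F)F)cc1`) gives 3800 nM
- compound 2 (`CC(C)CNC(=N)NC(=N)Nc1ccc(F)c(F)c1`) gives 29700 nM

Of these two measurements, compound 2 holds the higher number (29700 nM) and so shows the weaker inhibition. Compound 1 stands lower (3800 nM), a gap beyond the usual scatter. The two compounds differ in more than one place, so this gap cannot be tied to any single change.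

Compound 3 (`N=C(NC(=N)NC1CCCC1)Nc1ccc(F)c(F)c1`) keeps the rest of compound 2 but carries cyclopentyl in place of isobutyl on an amine nitrogen. Among the measured compounds shown here, no pair of measured compounds isolates this change in this assay. For the measured compounds named here, the only guide is that cyclopentyl already occurs in compound 1 (3800 nM), which is thin support. A moderate move towards a lower number is therefore expected, beyond the scatter but not a large one. The estimated size of the step is a 3.0-fold lower number from compound 2 to compound 3 (0.47 log units; beyond the scatter) (towards stronger inhibition). For compound 3 the estimated value is 10000 nM (expected range 4000 nM to 25000 nM).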

Compound 3, half-maximal inhibitory concentration: 16800 nM
Beside the measured number, compound 3's estimate is 1.7-fold (0.23 log units) below it; the range from low to high includes it.
By their numbers in this assay, from the lowest: compound 1; then compounds 3 and 2 (each within the scatter of the next).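

In this assay, the exchange of isobutyl for cyclopentyl on an amine nitrogen can now be read on its own, which neither compound 1 nor compound 2 allowed. The result is a 1.8-fold lower number from compound 2 to compound 3 (0.25 log units; within the scatter), so on the core of compound 2 this position does not separate isobutyl, which has no ring, from cyclopentyl, with its five-membered non-aromatic ring of carbon. The data at hand offer no explanation for this result.

The compounds shown leave open whether cyclopentyl and isobutyl would also stay this close on the core of compound 1, since the step is read on one core only, and so how far the outcome holds beyond that core. They also leave open how this position would respond to groups further from these two, such as a cyclohexyl ring, a longer chain like n-hexyl, or a chain ending in an amine or a carboxylic acid, as both groups compared here are small carbon groups with no hydrogen-bond donors or acceptors.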